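Compound 4 in the antiproliferative series: an amine for an ester

The source may report more compounds than this note shows. Statements on the series, on what has been measured and on what is new or still open speak of the compounds shown alone.

Compound 1 `CCn1c(C(=O)N[C@@H](C)C(=O)OC)ccc1C(CC)(CC)c1ccc(OCS(=O)(=O)c2ccccc2)c(C)c1`: 43700 nM
Compound 2 `CCn1c(C(=O)NCC(=O)OC)ccc1C(CC)(CC)c1ccc(OCS(=O)(=O)c2ccccc2)c(C)c1`: > 50000 nM
Compound 3 `CCn1c(C(=O)N[C@@H](CC(=O)OC)C(=O)OC)ccc1C(CC)(CC)c1ccc(OCS(=O)(=O)c2ccccc2)c(C)c1`: > 50000 nM

All three results come from a functional assay on MCF7 cells (Homo sapiens) for antiproliferative activity, read by MTT assay, with a stated time of 24 h; a higher number here means a weaker inhibitor, a lower number a stronger inhibitor. Compound 2 has no number, only a limit: it stands at the limit of > 50000 nM in this assay, at which 2 of the 3 values shown sit. Compound 3 also reports only a limit.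

Compound 4 `CCn1c(C(=O)NCCN)ccc1C(CC)(CC)c1ccc(OCS(=O)(=O)c2ccccc2)c(C)c1` has not yet been measured. The change from compound 2 is aminomethyl in place of methoxycarbonyl on a saturated chain carbon bound to an amide-type nitrogen. Cut one bond further out, ((methoxycarbonyl)methyl)carbamoyl gives way to (2-aminoethyl)carbamoyl.

Among the measured compounds shown here, three measured steps concern this side chain, though none removes the methoxycarbonyl group. The first is an at least 1.1-fold higher number from compound 1 to compound 2 (0.05 log units; that floor lies within the scatter). The second is an at least 1.1-fold higher number from compound 1 to compound 3 (0.05 log units; that floor lies within the scatter). The third is a step that the two limits leave unreadable from compound 2 to compound 3. Together they give no size for the present change, so only a small step of unknown direction is expected in this assay. For the measured compounds named here, compound 1 at 43700 nM provides the only number in the set, so the expectation stays close to it.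

The expected change is an at least 1.1-fold lower number from compound 2 to compound 4 (0.04 log units; that floor lies within the scatter). Compound 4 is expected at 45000 nM, with an estimated range from 15000 nM to 100000 nM.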

Compound 4, half-maximal inhibitory concentration: 6470 nM
Beside the measured number, compound 4's estimate is 7.0-fold (0.84 log units) above it; the whole stated range lies above it.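

In this assay, among the compounds shown here, this side chain now moves the result beyond the scatter, which the earlier steps among the esters did not show: their floors lay within it or could not be read. Aminomethyl in place of methoxycarbonyl gives an at least 7.7-fold lower number from compound 2 to compound 4 (0.88 log units; beyond the scatter) on a saturated chain carbon bound to an amide-type nitrogen, while 2-aminoethyl in place of the larger ester-bearing groups gives an at least 7.7-fold lower number from compound 3 to compound 4 (0.88 log units; beyond the scatter) and a 6.8-fold lower number from compound 1 to compound 4 (0.83 log units; beyond the scatter) on that amide-type nitrogen. The first two of these steps are floors, since compound 2 and compound 3 are held only at a limit of the assay: the limit of > 50000 nM in this assay, at which 2 of the 4 values shown sit.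

Only one amine is shown, so it remains open whether the change follows from gaining the amine or from losing the methyl ester. A carboxylic acid on the same carbon, or an amine on a longer chain, could help separate the two.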